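This account rests on a few compounds, and the source may have more. Where it says the series, first, only, none or still open, it means among the compounds named here.

Working notes on the series. In an ADME assay on microsomes from liver (Rattus norvegicus) for metabolic stability, with a stated time of 10 min (on this read-out lower numbers stand for a less stable compound and higher numbers for a more stable compound), compound 1 `CCCCCNc1nc(Nc2ccc([N+](=O)[O-])cc2)nc(OCC(F)(F)F)n1` gives 35%. Compound 2 `CC(C)C(=O)NCCS(=O)(=O)NC(=O)c1ccc(Nc2nc(NC3(c4ccc(Cl)cc4)CC3)nc(OCC(F)(F)F)n2)cc1` gives 84% in this assay, and compound 3 `O=C(NS(=O)(=O)c1ccccc1)c1ccc(Nc2nc(NC3(c4ccc(Cl)cc4)CC3)nc(OCC(F)(F)F)n2)cc1` gives 100%. Compound 3 therefore stands highest of the three numbers; compound 2 is nearest to it and compound 1 furthest, both gaps beyond the scatter. Going by the values given here, the only single-point step measured so far is a number 16 percentage points higher from compound 2 to compound 3 (beyond the scatter), a change of the group on the sulfonyl sulfur.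

Compound 4 `Cc1ccccc1S(=O)(=O)NC(=O)c1ccc(Nc2nc(NC3(c4ccc(Cl)cc4)CC3)nc(OCC(F)(F)F)n2)cc1` is not yet measured. Against compound 3 the change is methyl in place of hydrogen on an aromatic carbon, on the phenyl of the phenylsulfonyl group. Among the compounds with values here, no measured step touches this aromatic carbon; the step from compound 2 to compound 3 exchanged the whole substituent on the sulfonyl sulfur and went upward, and it is the only guide to this end of the molecule. Compound 3 already gives 100%, so no room upward remains, and for a methyl on an aromatic carbon the expectation in this assay is a step of none beyond the scatter, with a small decrease possible. The step of a number 6 percentage points lower from compound 3 to compound 4 (within the scatter) is thus expected to be small. Compound 4 is estimated at 94%, within 80% to 100%.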

Compound 4, percent of the compound remaining: 100%
Estimate against measurement, compound 4: 6 percentage points below, within the range that was stated.
By their numbers in this assay, from the lowest: compound 1; then compound 2; then compounds 3 and 4 (each within the scatter of the next).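

Going by these compounds alone, the methyl on an aromatic carbon, ortho to a large group, gives the first reading at this position in this assay: no change at the digits printed from compound 3 to compound 4 (within the scatter), so this added carbon on the phenyl of the phenylsulfonyl group costs nothing measurable here. The exchange on the sulfonyl sulfur also holds with the methyl in place: 2-methylphenyl in place of 2-((isopropylcarbonyl)amino)ethyl gives a number 16 percentage points higher from compound 2 to compound 4 (beyond the scatter), which matches a number 16 percentage points higher from compound 2 to compound 3 (beyond the scatter), so two aryl groups on the sulfonyl sulfur now stand above that amide-bearing chain, not one. Nothing on hand bears on why the methyl leaves the number in place.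

With compound 3 at 100% and compound 4 at 100%, the read-out has no room upward, so only a loss could show at this position and any gain from the methyl stays out of sight. From the compounds shown here alone, whether a larger or differently built group on this aromatic carbon, such as a methoxy, a chloro or a carboxylic acid, would hold the number remains open.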